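This account rests on a few compounds, and the source may have more. Where it says the series, first, only, none or still open, it means among the compounds named here.

Compound 1, `COc1cc(/C=C/c2cc(/C=C/c3cc(OC)c(OC)c(OC)c3)nc(OCCCCBr)n2)cc(OC)c1OC`, gives > 20000 nM in a functional assay on A549 cells (Homo sapiens) for cytotoxicity, read by fluorescence and resazurin assay, with a stated time of 48 h; a lower number here means a stronger inhibitor, a higher number a weaker inhibitor; this is a limit of the assay. Compound 3, `COc1cc(/C=C/c2cc(/C=C/c3cc(OC)c(OC)c(OC)c3)nc(OCCCCCBr)n2)cc(OC)c1OC`, gives > 20000 nM in this assay, again a limit. Compound 2, `COc1ccc(/C=C/c2cc(/C=C/c3ccc(OC)c(OC)c3)nc(OCCCCCCBr)n2)cc1OC`, gives > 20000 nM in this assay, also a limit.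

Compound 3 and compound 1 differ by bromo in place of bromomethyl on a saturated chain carbon, four bonds along the chain from an oxygen on an aromatic ring, and the step that the two limits leave unreadable from compound 3 to compound 1 cannot be read because of the limit of > 20000 nM in this assay, at which 3 of the 3 values shown sit. The unmeasured compound 4, `COc1ccc(/C=C/c2cc(/C=C/c3ccc(OC)c(OC)c3)nc(OCCCCCBr)n2)cc1OC`, stands to compound 2 as compound 1 stands to compound 3: the change is bromo in place of bromomethyl on a saturated chain carbon, five bonds along the chain from an oxygen on an aromatic ring, the same kind of change, but the place is not identical, since it sits five bonds rather than four bonds along the chain from the oxygen on the aromatic ring. The difference between the cores of compound 2 and compound 3 is not broken down here.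

Because (the limit of > 20000 nM in this assay, at which 3 of the 3 values shown sit), the expected step that the limit leaves unreadable from compound 2 to compound 4 is taken as small, with compound 4 most likely staying at the limit. Compound 4 is therefore estimated at 40000 nM in this assay, with an expected range from 15000 nM to 150000 nM.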

Compound 4, half-maximal inhibitory concentration: > 20000 nM
Compound 4 gave a limit, no number; the forecaster's own chance of this, stated with the estimate: 85%; the middle value does not contradict the limit.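

Compound 4 stays at the limit of the assay, as compound 2 does, so the step between compound 2 and compound 4 cannot be read and no new step follows from this result: the limit of > 20000 nM in this assay, at which 4 of the 4 values shown sit.

The compounds shown leave open whether any of these bromo-ended chains, on either core, would give a measurable number in this assay.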